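This account rests on a few compounds, and the source may have more. Where it says the series, first, only, none or still open, it means among the compounds named here.

Compound 1 `O=C(Nc1ccc(F)cc1)Nc1nc(-c2cc3ccccc3o2)cs1` gives 1130 nM in a physicochemical assay, with a stated time of 6 min; on this read-out lower numbers stand for stronger inhibition and higher numbers for weaker inhibition. Compound 2 `O=C(Nc1ccc(F)cc1)Nc1nc(-c2cc3cc(Br)ccc3o2)cs1` carries a bromo in place of hydrogen on an aromatic carbon; in this assay compound 2 reaches only the limit of > 200000 nM, which is not a number but the edge of what the assay can report, so compound 2 stands at the weak end of the values shown. Compound 3 `O=C(Nc1ccc(I)cc1)Nc1nc(-c2cc3ccccc3o2)cs1` gives 62000 nM. Both measured steps ran the same way: an at least 170-fold higher number from compound 1 to compound 2 (2.24 log units; beyond the scatter) and a 55-fold higher number from compound 1 to compound 3 (1.74 log units; beyond the scatter). Compound 4 `O=C(Nc1ccc([N+](=O)[O-])cc1)Nc1nc(-c2cc3cc(Br)ccc3o2)cs1` differs from compound 2 by nitro in place of fluoro on an aromatic carbon. The step from compound 1 to compound 3 shows that swapping the group on this aromatic carbon weakened inhibition sharply, and compound 2 already sits at a limit. Compound 4 is therefore expected to stay near that limit, a step that the limit leaves unreadable from compound 2 to compound 4. The estimate for compound 4 is 250000 nM, expected within 60000 nM to 1000000 nM.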

Compound 4, half-maximal inhibitory concentration: > 200000 nM
Compound 4 was reported as a limit; the forecaster's own chance of this, stated with the estimate: 75%; the middle value does not contradict the limit.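

Compound 2 and compound 4 both stand as limits of the assay rather than as numbers, so no step can be read from compound 2 to compound 4: the limit of > 200000 nM in this assay, at which 2 of the 4 values shown sit.

The compounds shown leave open whether nitro in place of fluoro changes inhibition at all.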